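Swapping a Branched Chain for a Ring in Compound 3

A few compounds are considered here, and "the series" means these few. Any claim that something is new, unique, unknown or untested is made for them only; others in the source may bear on it.

Going by the values given here, compound 2 `CC(C)C(NC(=S)NCc1ccc(C(C)(C)C)cc1)c1ccc(NS(C)(=O)=O)c(F)c1` gives 339 nM in an assay on CHO cells for displacement of a labelled ligand from transient receptor potential cation channel subfamily V member 1 (Rattus norvegicus) (a higher number here means a weaker inhibitor, a lower number a stronger inhibitor), the highest of the two numbers measured so far. Its nearest neighbour is compound 1 `CCC(NC(=S)NCc1ccc(C(C)(C)C)cc1)c1ccc(NS(C)(=O)=O)c(F)c1`, which gives 230 nM in this assay; the step of a 1.5-fold higher number from compound 1 to compound 2 (0.17 log units; within the scatter) lies within the scatter, so these two compounds cannot be told apart on the numbers at hand. Compound 3 `CC(C)(C)c1ccc(CNC(=S)NC(c2ccccc2)c2ccc(NS(C)(=O)=O)c(F)c2)cc1` differs from compound 2 by phenyl in place of isopropyl on a saturated chain carbon bound to an amide-type nitrogen and an aromatic carbon. Among the compounds with values here, no measured step replaces a chain with a ring here; the only step available, a 1.5-fold higher number from compound 1 to compound 2 (0.17 log units; within the scatter), adds a methyl to the chain and barely moves the number. That step bears on the present change only loosely, so the expected step of a 1.1-fold lower number from compound 2 to compound 3 (0.05 log units; within the scatter) is one of no clear direction beyond the scatter, carried with wide uncertainty. Compound 3 is therefore estimated at 300 nM, with a range from 90 nM to 1000 nM.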

Compound 3, inhibition constant: 100 nM
Compound 3: the middle estimate sits 3.0-fold (0.48 log units) above what was measured; measured number inside the range.
By their numbers in this assay, from the lowest: compound 3; then compounds 1 and 2 (each within the scatter of the next).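

Going by these compounds alone, at this saturated chain carbon bound to an amide-type nitrogen and an aromatic carbon, the earlier compounds offered only a chain change that could not be told apart from the scatter, whereas a ring now gives a clear shift. In this assay, phenyl in place of isopropyl gives a 3.4-fold lower number from compound 2 to compound 3 (0.53 log units; beyond the scatter) and phenyl in place of ethyl gives a 2.3-fold lower number from compound 1 to compound 3 (0.36 log units; beyond the scatter), which makes compound 3 the strongest inhibitor of the three. Nothing at hand explains why the number falls.

The compounds shown leave open whether the ring has to be aromatic, a question that cyclohexyl at this position would address. On these data alone, it also remains open whether a phenyl carrying a methoxy group or a chlorine atom, or a pyridyl ring, would lower the number further.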